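From methyl to methoxy: compound 3 to compound 4

This account rests on a few compounds, and the source may have more. Where it says the series, first, only, none or still open, it means among the compounds named here.

Three compounds share one core and differ in a single group on an aromatic carbon: trifluoromethyl in compound 1 (`Cc1ccc(C(=O)CCN2CCN(c3ccc(C(F)(F)F)cc3)CC2)cc1`), chloro in compound 2 (`Cc1ccc(C(=O)CCN2CCN(c3ccc(Cl)cc3)CC2)cc1`) and nitro in compound 3 (`Cc1ccc(C(=O)CCN2CCN(c3ccc([N+](=O)[O-])cc3)CC2)cc1`). In an ADME assay on Vero cells (Chlorocebus sabaeus) for cytotoxicity, read by resazurin assay, with a stated time of 72 h (on this read-out lower numbers stand for stronger inhibition and higher numbers for weaker inhibition), compound 1 gives 140000 nM, compound 2 gives 184000 nM and compound 3 gives 235000 nM. Compound 3 therefore cannot be told apart from the other two. The measured steps are a 1.3-fold higher number from compound 1 to compound 2 (0.12 log units; within the scatter), a 1.3-fold higher number from compound 2 to compound 3 (0.11 log units; within the scatter) and a 1.7-fold higher number from compound 1 to compound 3 (0.22 log units; within the scatter), and each stays inside the normal spread of repeated measurements.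

Compound 4 (`COc1ccc(C(=O)CCN2CCN(c3ccc([N+](=O)[O-])cc3)CC2)cc1`) keeps the nitro group of compound 3 but changes a different place in the molecule: methoxy in place of methyl on an aromatic carbon, para to a large group (methoxy in place of methyl on an aromatic carbon). Going by the values given here, no measured step tests this swap directly. The nearest guide is the exchange of groups at the other site, where even the largest step, a 1.7-fold higher number from compound 1 to compound 3 (0.22 log units; within the scatter), stays within the scatter. On that limited evidence, no step beyond the scatter is expected in this assay, and the expected step is a 1.1-fold lower number from compound 3 to compound 4 (0.03 log units; within the scatter). For compound 4 the estimated value is 220000 nM, with an expected range of 110000 nM to 400000 nM.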

Compound 4, half-maximal inhibitory concentration: 587000 nM
Compound 4: the middle estimate sits 2.7-fold (0.43 log units) below what was measured; measured number above the stated range.
By their numbers in this assay, from the lowest: compounds 1, 2 and 3 (each within the scatter of the next); then compound 4.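

In this assay, putting methoxy in place of methyl on the aromatic carbon para to a large group gives a 2.5-fold higher number from compound 3 to compound 4 (0.40 log units; beyond the scatter) and so moves the read-out toward weaker inhibition, by a modest amount that lies beyond the scatter. The exchanges among trifluoromethyl, chloro and nitro at the other site all stayed within the scatter, so this 4-methylphenyl to 4-methoxyphenyl change is the only single change shown here that can be told apart from the noise of repeated measurements. No measured property among these compounds accounts for the step, so what lies behind it remains unknown.

On these data alone, the step rests on a single pair in which nitro is held constant, so it remains open whether methoxy would shift the number in the same direction and by a similar size with chloro or trifluoromethyl at the other site. As far as these compounds go, it is also open whether the change is specific to methoxy or would be matched at the same position by a hydroxyl group, an ethoxy group or an amine.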